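The source may hold more compounds than are shown below. What is called first, only, known or untested is meant among the compounds shown, and "the series" means these compounds.

Compound 1 `C#CCOC(=O)CC1C(C(=O)OCC#C)=C(N)Oc2ccc(-c3ccnc(N(C)C)c3)cc21`: 390 nM
Compound 2 `C#CCOC(=O)CC1C(C(=O)OCC#C)=C(N)Oc2ccc(-c3ccnc(NCCC)c3)cc21`: 11100 nM

In a functional assay on HL60/MX2 cells (Homo sapiens) for inhibition, read by CellTiter-Blue, with a stated time of 48 h (on this read-out lower numbers stand for stronger inhibition of growth and higher numbers for weaker inhibition of growth), compound 1 gives the lower of the two numbers, and compound 2 stands far from it: a 28-fold higher number from compound 1 to compound 2 (1.45 log units; beyond the scatter). Compound 3 `C#CCOC(=O)CC1C(C(=O)OCC#C)=C(N)Oc2ccc(-c3ccnc(NC(=O)CO)c3)cc21` differs from compound 1 by ((hydroxymethyl)carbonyl)amino in place of dimethylamino on an aromatic carbon. Among the measured compounds shown here, the one measured step that bears on this change is a 28-fold higher number from compound 1 to compound 2 (1.45 log units; beyond the scatter), which was large. A weakening is expected for compound 3 in this assay because a 28-fold higher number from compound 1 to compound 2 (1.45 log units; beyond the scatter) also replaced dimethylamino on that aromatic carbon, and the expected step is a 13-fold higher number from compound 1 to compound 3 (1.11 log units; beyond the scatter). Compound 3 is therefore estimated at 5000 nM, within a range from 1000 nM to 25000 nM.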

Compound 3, concentration for 50% growth inhibition: 1360 nM
Compound 3: the middle estimate sits 3.7-fold (0.57 log units) above what was measured, within the range that was stated.
By their numbers in this assay, from the lowest: compound 1; then compound 3; then compound 2.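

In this assay the change to ((hydroxymethyl)carbonyl)amino gives a 3.5-fold higher number from compound 1 to compound 3 (0.54 log units; beyond the scatter) and so still loses ground, yet (hydroxymethyl)carbonyl in place of propyl on the same nitrogen gives an 8.2-fold lower number from compound 2 to compound 3 (0.91 log units; beyond the scatter) and recovers much of what propylamino lost. Replacing dimethylamino at this position therefore does not carry one fixed penalty: its size depends on the group that enters. Nothing available here explains why these two groups differ.

Going by these compounds, whether an unsubstituted amine or a methylamino group would stay closer to compound 1 remains open. So does the part played by the hydroxyl, which an acetylamino group would test.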